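From Benzyl to 4-Fluorobenzyl: Compound 2 to Compound 3

The compounds below may be only part of what the source reports. "The series", "measured", "known", "first", "only" and "open" are said of these compounds alone.

For the measured compounds named here, in an ADME assay on A549 cells (Homo sapiens) for cytotoxicity, read by resazurin assay, with a stated time of 48 h (on this read-out higher numbers stand for lower toxicity in this test and lower numbers for higher toxicity in this test), compound 1 `CC(C)CNc1ccc(NC(=O)c2cc(Cl)ccc2O)c(Cl)c1` gives 60000 nM, while compound 2 `O=C(Nc1ccc(NCc2ccccc2)cc1Cl)c1cc(Cl)ccc1O` gives 19700 nM, the lower of the two numbers so far. Compound 3 `O=C(Nc1ccc(NCc2ccc(F)cc2)cc1Cl)c1cc(Cl)ccc1O` differs from compound 2 by one small change: fluoro in place of hydrogen on an aromatic carbon. This places fluoro in place of hydrogen on an aromatic carbon, turning benzyl into 4-fluorobenzyl. Going by the values given here, no measured step involves fluoro. Among the compounds with values here, the only guide is a 3.0-fold lower number from compound 1 to compound 2 (0.48 log units; beyond the scatter), a modest step from phenyl in place of isopropyl. The far smaller change here suggests no shift beyond the scatter in this assay, so the expected move is a 1.2-fold lower number from compound 2 to compound 3 (0.06 log units; within the scatter). For compound 3, the estimated value is 17000 nM, with an expected range of 8500 nM to 34000 nM.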

Compound 3, half-maximal cytotoxic concentration: 54400 nM
Compound 3: middle estimate off by 3.2-fold (0.51 log units), on the low side; the measured number lies above the stated range.
By their numbers in this assay, from the lowest: compound 2; then compounds 3 and 1 (each within the scatter of the next).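

Compound 3 shows that this position on the benzyl ring is not neutral in this assay: adding a single fluoro para to a large group gives a 2.8-fold higher number from compound 2 to compound 3 (0.44 log units; beyond the scatter). The other step, a 1.1-fold lower number from compound 1 to compound 3 (0.04 log units; within the scatter), means that 4-fluorophenyl and isopropyl on the saturated chain carbon cannot be told apart here. No available evidence accounts for the effect of fluoro. Still open, going by these compounds, is whether chloro, methoxy or an amine at the same ring carbon would give a similar step, and whether fluoro at another carbon of this ring would do so.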